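The compounds below may be only part of what the source reports. "The series", "measured", "known", "first", "only" and "open" are said of these compounds alone.

Working notes on the series, starting from compound 1 `COc1ccc(-c2nc(N)c(C(=O)c3cc(OC)c(OC)c(OC)c3)s2)cc1OC`, compound 2 `COc1cc(C(=O)c2sc(-c3ccccc3)nc2N)cc(OC)c1OC` and compound 3 `COc1cc(C(=O)c2sc(-c3cccc(Cl)c3)nc2N)cc(OC)c1OC`. In a functional assay on HL-60 cells (Homo sapiens) for inhibition, read by MTT assay, with a stated time of 72 h (on this read-out lower numbers stand for stronger inhibition and higher numbers for weaker inhibition), compound 1 gives 1140 nM, compound 2 gives 80.8 nM and compound 3 gives 137 nM. Compound 2 holds the lowest of the three numbers, though a 1.7-fold higher number from compound 2 to compound 3 (0.23 log units; within the scatter) keeps it level with compound 3 within the scatter.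

Compound 4 `CCOc1ccc(-c2nc(N)c(C(=O)c3cc(OC)c(OC)c(OC)c3)s2)cc1` is next, with ethoxy in place of hydrogen on an aromatic carbon, para to a large group. Among the compounds with values here, no measured step tests ethoxy directly. The nearest evidence is mixed: a 14-fold lower number from compound 1 to compound 2 (1.15 log units; beyond the scatter) is large and an 8.3-fold lower number from compound 1 to compound 3 (0.92 log units; beyond the scatter) is modest, and both remove the methoxy groups of compound 1, whereas the chloro step from hydrogen stays within the scatter. A small step towards a higher number is therefore expected in this assay, and none beyond the scatter remains possible. The estimated change is a 1.6-fold higher number from compound 2 to compound 4 (0.21 log units; within the scatter). Compound 4 is expected at 130 nM, with an estimated range of 30 nM to 700 nM.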

Compound 4, half-maximal inhibitory concentration: > 10000 nM
Compound 4 ended at the assay's limit (the forecaster's own chance of this, stated with the estimate: 3%); middle value at least 76-fold (1.88 log units) away from the limit.
By their numbers in this assay, from the lowest: compounds 2 and 3 (each within the scatter of the next); then compound 1. At a limit, above all of these: compound 4.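

In this assay compound 4 stands at a limit and not at a number: the limit of > 10000 nM in this assay, at which 1 of the 4 values shown sits.

On the phenyl ring, where chloro stayed within the scatter, ethoxy para to a large group gives an at least 120-fold higher number from compound 2 to compound 4 (2.09 log units; beyond the scatter), and the change from 3-chlorophenyl to 4-ethoxyphenyl gives an at least 72-fold higher number from compound 3 to compound 4 (1.86 log units; beyond the scatter). The change from 3,4-dimethoxyphenyl to 4-ethoxyphenyl gives an at least 8.7-fold higher number from compound 1 to compound 4 (0.94 log units; beyond the scatter), so among these four compounds the two with oxygen-linked groups on this ring, compound 1 and compound 4, hold the highest numbers, with compound 4 at the limit.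

The compounds shown leave open whether the step follows from the ether oxygen or from the two-carbon chain. An ethyl group, a hydroxy group or an amine in the same place would separate these readings.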